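A few compounds are considered here, and "the series" means these few. Any claim that something is new, unique, unknown or untested is made for them only; others in the source may bear on it.

The measured compounds in this series:

compound 1 `Cc1cn([C@@H]2O[C@@H]3COC(=O)[C@]3(OS(C)(=O)=O)[C@H]2O)c(=O)[nH]c1=O` — >= 250000 nM
compound 2 `COC(=O)NC1=CS(=O)(=O)O[C@@]12[C@@H](CO[Si](C)(C)C(C)(C)C)O[C@@H](n1cc(C)c(=O)n(C)c1=O)[C@@H]2O[Si](C)(C)C(C)(C)C` — 29900 nM
compound 3 `Cc1cn([C@@H]2O[C@@H]3COC4(O)CS(=O)(=O)O[C@@]34[C@H]2O[Si](C)(C)C(C)(C)C)c(=O)[nH]c1=O` — 100000 nM

In a functional assay on MT4 cells (Homo sapiens) (on this read-out higher numbers stand for lower toxicity in this test and lower numbers for higher toxicity in this test), compound 2 gives 29900 nM, the lower of the two numbers recorded. Compound 3 gives 100000 nM in this assay, a higher number, and the gap between the two lies beyond the usual scatter of repeated measurements. Compound 1 stands apart: its result of >= 250000 nM in this assay is a limit and not a number, and the limit of >= 250000 nM in this assay, at which 1 of the 3 values shown sits, is all that can be said of it.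

Compound 4 `COC(=O)CCNC1=CS(=O)(=O)O[C@@]12[C@@H](CO[Si](C)(C)C(C)(C)C)O[C@@H](n1cc(C)c(=O)n(C)c1=O)[C@@H]2O[Si](C)(C)C(C)(C)C` has not yet been measured. It differs from compound 2 in one place, counted as 2-(methoxycarbonyl)ethyl in place of methoxycarbonyl on an amine nitrogen. Among the measured compounds shown here, no pair of measured compounds in this set differs in this way, so there is no measured step to lean on for the direction or size of the change. With nothing in the data pointing one way or the other, compound 4 is expected to sit close to compound 2, with a step of a 1.2-fold higher number from compound 2 to compound 4 (0.07 log units; within the scatter) that stays within the scatter. Compound 4 is therefore estimated at 35000 nM in this assay, with a range from 12000 nM to 110000 nM.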

Compound 4, half-maximal cytotoxic concentration: > 250000 nM
Compound 4: a limit, no number; the forecaster's own chance of this, stated with the estimate: 10%; at least 7.1-fold (0.85 log units) between middle value and limit.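

Until now nothing showed whether the group on this amine nitrogen mattered for this read-out, but putting 2-(methoxycarbonyl)ethyl in place of methoxycarbonyl gives an at least 8.3-fold higher number from compound 2 to compound 4 (0.92 log units; beyond the scatter) in this assay. The result for compound 4 is a limit and not a number: the limit of > 250000 nM in this assay, at which 1 of the 4 values shown sits. The two groups match in hydrogen-bond donors, hydrogen-bond acceptors, double bonds outside aromatic rings and net charge, and neither holds a ring, so a change that leaves those counts alone and adds only carbon to the group is enough to move the result beyond the scatter at this place.

The size of the step has only a lower bound, and one pair cannot separate the effect of the longer carbon chain from that of moving the ester group away from the amine nitrogen. A plain ethyl group, a carboxylic acid in place of the ester, or a longer chain ending in the same ester on this nitrogen would each be needed to tell which part of the change carries the step.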